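A few compounds are considered here, and "the series" means these few. Any claim that something is new, unique, unknown or untested is made for them only; others in the source may bear on it.

Measured compounds:
compound 1 `CC(=O)Oc1ccccc1C(=O)NCC[Se]C#N`, 6000 nM
compound 2 `CC(=O)Oc1ccccc1C(=O)OCC[Se]C#N`, 34300 nM
compound 3 `CC(=O)Oc1ccccc1C(=O)[Se]CC[Se]C(=O)c1ccccc1OC(C)=O`, 7600 nM

In a functional assay on MDA-MB-231 cells (Homo sapiens) for antiproliferative activity, read by MTT assay, with a stated time of 72 h (on this read-out higher numbers stand for weaker inhibition and lower numbers for stronger inhibition), compound 2 gives the highest number of the three; compound 3 lies closest to it, and compound 1 is furthest away, both with lower numbers and both beyond the scatter. Compound 4 `CC(=O)Oc1ccccc1C(=O)[Se]CC[Se]C#N` has not yet been measured. It differs from compound 2 in one place: a group of 6 heavy atoms (3 carbon, 1 nitrogen, 2 selenium; no ring) in place of a group of 6 heavy atoms (3 carbon, 1 nitrogen, 1 oxygen, 1 selenium; no ring), on a carbonyl carbon. For the measured compounds named here, only one measured step touches the same carbonyl carbon, a 5.7-fold higher number from compound 1 to compound 2 (0.76 log units; beyond the scatter), where exchanging the group on that carbon moved the number beyond the scatter. Compound 3, which carries a selenium-linked group on each of its two carbonyl carbons, gives 7600 nM in this assay, a lower number than compound 2. On that basis the exchange leading to compound 4 is expected to lower the number, toward the values shown by compound 1 and compound 3, and the step from compound 2 to compound 4 is estimated as a 3.8-fold lower number from compound 2 to compound 4 (0.58 log units; beyond the scatter). Compound 4 is therefore expected to give about 9000 nM in this assay, with a range from 3000 nM to 30000 nM.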

Compound 4, half-maximal inhibitory concentration: 18600 nM
Compound 4: the middle estimate sits 2.1-fold (0.32 log units) below what was measured; measured number inside the range.
By their numbers in this assay, from the lowest: compounds 1 and 3 (each within the scatter of the next); then compounds 4 and 2 (each within the scatter of the next).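

In this assay, placing the group with 2 selenium atoms on the carbonyl carbon instead of the group holding oxygen gives a 1.8-fold lower number from compound 2 to compound 4 (0.27 log units; within the scatter) and so does not separate these two groups at this position. Exchanging selenium for oxygen in this link therefore does not bring the number toward that of compound 1. Compound 1 stands apart from both compounds, with a 5.7-fold higher number from compound 1 to compound 2 (0.76 log units; beyond the scatter) and also a 3.1-fold higher number from compound 1 to compound 4 (0.49 log units; beyond the scatter) on the same carbonyl carbon, which makes the group holding the amide hydrogen, rather than either of the other two groups, the one that differs in this small set. Nothing measured here accounts for that difference.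

The compounds shown leave open whether the lower number of compound 1 would survive a methyl group on the amide nitrogen, which would test whether the amide hydrogen matters. They also leave open how a sulfur atom in the link on the carbonyl carbon, or a longer chain leading to the selenium-bound nitrile, would behave at this position.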